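The source may hold more compounds than are shown below. What is called first, only, known or untested is meant among the compounds shown, and "the series" means these compounds.

Working notes on the series. Compound 1 `CCOC(=O)C(=O)Nc1cccccc1=O` is the reference point: in a functional assay on the whole organism (strain Sprague-Dawley CD) for inhibition, with Rattus norvegicus as the target, read by paw edema, at a dose of 30 mg/kg by the intraperitoneal route (on this read-out lower numbers stand for a weaker effect and higher numbers for a stronger effect at the one dose given), compound 1 gives 84%, the highest of the two numbers in hand. Among the compounds with values here, the only comparator is compound 2 `CCOC(=O)C(=O)Nc1ccc(OC)ccc1=O`, which gives 8%; the step of a number 76 percentage points lower from compound 1 to compound 2 (beyond the scatter) came with methoxy in place of hydrogen on an aromatic carbon.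

Compound 3 `O=C(Nc1cccccc1=O)C(=O)Oc1ccccc1` is next to be measured. Its change from compound 1 is phenyl in place of ethyl on an oxygen next to a carbonyl group. Within the data shown here, no measured step touches the oxygen next to the carbonyl group; the single step in hand, from compound 1 to compound 2, sits on the aromatic carbon of the shared core and cannot be carried over to a change on the ester oxygen. The expectation therefore rests on compound 1 alone, widened for the lack of any matched comparison.

The step of a number 24 percentage points lower from compound 1 to compound 3 (beyond the scatter) is the expected shift. Compound 3 is expected to give 60%, within a range of 20% to 90%.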

Compound 3, a percentage reported as inhibition, in the whole organism at one dose (the size of the read-out at that dose, not a potency): 73%
The estimate for compound 3 lay 13 percentage points below the measured number, within the range that was stated.
By their numbers in this assay, from the lowest: compound 2; then compound 3; then compound 1.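

Within the data shown here, with only ethyl available before, this is the first reading at the oxygen next to a carbonyl group: in this assay, phenyl in place of ethyl came with a number 11 percentage points lower from compound 1 to compound 3 (beyond the scatter), a modest step. Compound 3 still gives 73%, so this position accepts a six-membered aromatic ring with much of the read-out at the one dose kept, and the step is smaller than a number 76 percentage points lower from compound 1 to compound 2 (beyond the scatter) on the aromatic carbon. Nothing at hand bears on why the phenyl step has this size.

With only ethyl and phenyl shown on this oxygen, it remains open how a longer chain such as butyl, a benzyl group or a free carboxylic acid would read. Also open, going by these compounds, is whether methoxy on the aromatic carbon would bring a similar loss alongside phenyl on the oxygen.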